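The compounds below may be only part of what the source reports. "The series", "measured", "known", "first", "only" and "open" are said of these compounds alone.

In a functional assay on HeLa cells (Homo sapiens) for inhibition, read by sulforhodamine B assay, with a stated time of 48 h (a higher number here means a weaker inhibitor of growth, a lower number a stronger inhibitor of growth), compound 1 `COC(=O)[C@@]1(C)CC[C@@H]2C3=C1CC[C@@H](C)[C@]3(C)Cc1c2[nH]c2ccc(C)cc12` gives 11000 nM, and compound 2 `COC(=O)[C@@]1(C)CC[C@@H]2C3=C1CC[C@@H](C)[C@]3(C)Cc1c2[nH]c2ccc(Br)cc12` gives 14000 nM. The step of a 1.3-fold higher number from compound 1 to compound 2 (0.10 log units; within the scatter) goes with the change (bromo in place of methyl on an aromatic carbon). Compound 3 `COC(=O)[C@@]1(C)CC[C@@H]2C3=C1CC[C@@H](C)[C@]3(C)C[C@@H]1c3cccc(C)c3N[C@H]21` rests on a different core, and the difference between the two cores is not broken down here. In this assay compound 3 gives 22000 nM, which lies within the scatter of both compound 1 and compound 2. Compound 4 `COC(=O)[C@@]1(C)CC[C@@H]2C3=C1CC[C@@H](C)[C@]3(C)C[C@@H]1c3cccc(Br)c3N[C@H]21` has not yet been measured in this assay. It differs from compound 3 by bromo in place of methyl on an aromatic carbon. This is the same kind of change as that from compound 1 to compound 2, though not the same: in compound 2 the bromo sits meta to a fused ring and para to a fused ring, whereas in compound 4 it sits ortho to a fused ring and meta to a fused ring. Since the like change gave only a 1.3-fold higher number from compound 1 to compound 2 (0.10 log units; within the scatter), a step of similar size is expected here. Compound 4 is estimated to show a 1.2-fold higher number from compound 3 to compound 4 (0.09 log units; within the scatter). Compound 4 is therefore expected to give 27000 nM in this assay, with a likely range from 12000 nM to 60000 nM.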

Compound 4, concentration for 50% growth inhibition: 22000 nM
For compound 4 the middle estimate is 1.2-fold (0.09 log units) above the measured one; the measured number falls inside the stated range.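

In this assay, putting bromo in place of methyl on an aromatic carbon of the core of compound 3 gives no change at the digits printed from compound 3 to compound 4 (within the scatter), and the two cores agree on this change: the same change on two cores in this assay, a 1.3-fold higher number (0.10 log units; within the scatter) from compound 1 to compound 2 and no change at the digits printed (within the scatter) from compound 3 to compound 4, 1.3-fold (0.10 log units) apart, within the scatter of two such steps

So in this small set, the exchange of methyl for bromo leaves the growth-inhibition number within the scatter on both cores, and the step on one core would have served as a fair guide to the step on the other. This does not show that the step is independent of the core in general, since only two pairs are shown and neither step lies beyond the scatter. Nor can the core be separated from position, as the bromo of compound 4 sits ortho to a fused ring and meta to a fused ring, unlike the bromo of compound 2.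

The compounds shown leave open whether an amine, a carboxylic acid or a longer chain on that aromatic carbon would give a step beyond the scatter. They also leave open whether such a step would carry from one core to the other.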